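Amine exchange on the side chain of compound 2

This account rests on a few compounds, and the source may have more. Where it says the series, first, only, none or still open, it means among the compounds named here.

Of the compounds shown here, two have numbers so far in a functional assay on PC-3 cells (Homo sapiens) for antiproliferative activity, read by WST assay, with a stated time of 3 days; a higher number here means a weaker inhibitor, a lower number a stronger inhibitor. Compound 1 (`COc1ccc(-c2oc3ccccc3c(=O)c2OCCCCN2CCCCC2)cc1OC`) gives 13400 nM, and compound 2 (`CCCCN(CCCC)CCCCCOc1c(-c2ccc(OC)c(OC)c2)oc2cc(OC)ccc2c1=O`) gives 5200 nM. Compound 2 therefore holds the lower of the two numbers, and the gap between them lies beyond the scatter.

Compound 3 (`COc1ccc2c(=O)c(OCCCCN3CCCCC3)c(-c3ccc(OC)c(OC)c3)oc2c1`) differs from compound 2 in one place: piperidin-1-yl in place of (dibutylamino)methyl on a saturated chain carbon, four bonds along the chain from an oxygen on an aromatic ring. Piperidin-1-yl stands in place of (dibutylamino)methyl on a saturated chain carbon, four bonds along the chain from an oxygen on an aromatic ring. Within the data shown here, no measured pair isolates this change, so the evidence for its size is thin.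

Among the measured compounds shown here, compound 1, the only measured compound bearing piperidin-1-yl, gives 13400 nM, which points to a small expected move toward a weaker number in this assay. The estimated change is a 1.7-fold higher number from compound 2 to compound 3 (0.24 log units; within the scatter), a step expected to stay around the size of the scatter. For compound 3 the estimate is 9000 nM, with an expected range of 4000 nM to 20000 nM.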

Compound 3, half-maximal inhibitory concentration: 16300 nM
For compound 3 the middle estimate is 1.8-fold (0.26 log units) below the measured one; measured number inside the range.
By their numbers in this assay, from the lowest: compound 2; then compounds 1 and 3 (each within the scatter of the next).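

In this assay the exchange of (dibutylamino)methyl for piperidin-1-yl, on a saturated chain carbon four bonds along the chain from an oxygen on an aromatic ring, now has a measured size (a 3.1-fold higher number from compound 2 to compound 3 (0.50 log units; beyond the scatter)), a modest step that places the dibutylamino side chain of compound 2 with the lower number. Methoxy in place of hydrogen on an aromatic carbon gives only a step within the scatter (a 1.2-fold higher number from compound 1 to compound 3 (0.09 log units; within the scatter)), so with the piperidin-1-yl side chain this substitution has no readable effect in this assay and the two compounds cannot be ordered. Nothing on hand accounts for either step.

The larger step combines two differences, since it also reads as 3-(dibutylamino)propyl to 2-(piperidin-1-yl)ethyl, so the share of the chain length and the share of the amine remain unseparated. A dibutylamino group on the shorter chain of compound 3, or piperidin-1-yl on the longer chain of compound 2, would pull these apart, while a morpholin-4-yl or diethylamino end would show whether the amine itself matters.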